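The source may report more compounds than this note shows. Statements on the series, on what has been measured and on what is new or still open speak of the compounds shown alone.

Measured compounds in an ADME assay on cells (Hepatocyte, Homo sapiens) for cytotoxicity, read by MTT assay, with a stated time of 90 min, tested at 100 uM; on this read-out lower numbers stand for a stronger effect and higher numbers for a weaker effect at the one concentration tested:
compound 1 `Cc1c(C)c2c(c(C)c1O)CCC(C)(COc1ccc(/C=C3\SC(=O)N(C)C3=O)cc1)O2` gives 147%
compound 2 `Cc1c(C)c2c(c(C)c1OC(=O)CCCCCCCNC(=O)OC(C)(C)C)CCC(C)(COc1ccc(/C=C3\SC(=O)NC3=O)cc1)O2` gives 79.3%
compound 3 `Cc1c(C)c2c(c(C)c1CCCCCCNC(=O)OCc1ccccc1)CCC(C)(COc1ccc(/C=C3\SC(=O)NC3=O)cc1)O2` gives 85.1%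

Compound 1 stands highest of these three numbers in this assay. Compound 3 lies nearest to it, with a number lower by a gap beyond the usual scatter, and compound 2 lies furthest, also lower by more than the scatter. Compound 4 `Cc1c(C)c2c(c(C)c1CCCCCCN)CCC(C)(COc1ccc(/C=C3\SC(=O)N(C)C3=O)cc1)O2` has not yet been measured. It differs from compound 1 in one place: 6-aminohexyl in place of hydroxy on an aromatic carbon. Compound 2 and compound 3, which both carry a long chain on the shared core, sit far below compound 1, so a downward step well beyond the scatter is expected from compound 1 to compound 4, estimated as a number 62 percentage points lower from compound 1 to compound 4 (beyond the scatter). Compound 4 is therefore expected to give about 85%, within an estimated range from 55% to 120%.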

Compound 4, a percentage reported as activity, at one concentration (the size of the read-out at that concentration, not a potency): 82.6%
Estimate against measurement, compound 4: 2.4 percentage points above, and the stated range covers the measured number.
By their numbers in this assay, from the lowest: compounds 2, 4 and 3 (each within the scatter of the next); then compound 1.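

For the compounds shown here, this is the first pair here that differs in one place only, so the effect of this position can be read directly. With the rest of the molecule unchanged, 6-aminohexyl in place of hydroxy on this aromatic carbon gives a number 64.4 percentage points lower from compound 1 to compound 4 (beyond the scatter) in this assay, a large step beyond the scatter. No measurement here explains this step.

From the compounds shown here alone, it remains open whether the step follows the loss of the hydroxy or the arrival of the chain. A plain hexyl chain without the amine, a shorter aminoalkyl chain or a chain ending in a carboxylic acid could help separate these.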